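Amine tail swap on the shared aryl-ether core

A few compounds are considered here, and "the series" means these few. Any claim that something is new, unique, unknown or untested is made for them only; others in the source may bear on it.

Measured compounds:
compound 1 `COc1cc2c(Oc3ccc(NC(=O)c4nnn(-c5ccccc5C)c4C)cc3F)ccnc2cc1OCCCN1CCCC1` — 380 nM
compound 2 `COc1cc2c(Oc3ccc(NC(=O)c4nnn(-c5ccccc5C(F)(F)F)c4C)cc3F)ccnc2cc1OCCCN1CCCC1` — 160 nM
compound 3 `COc1cc2c(Oc3ccc(NC(=O)c4nnn(-c5ccccc5C(F)(F)F)c4C(F)(F)F)cc3F)ccnc2cc1OCCCN1CCCC1` — 200 nM

All three have been run in a functional assay on A549 cells (Homo sapiens) for cytotoxicity, read by MTT assay, with a stated time of 72 h; on this read-out lower numbers stand for stronger inhibition and higher numbers for weaker inhibition. Compound 2 has the lowest number of the three. Its nearest neighbour is compound 3, the step of a 1.3-fold higher number from compound 2 to compound 3 (0.10 log units; within the scatter) staying within the scatter, so no order between these two can be claimed. The furthest is compound 1, and the step of a 2.4-fold lower number from compound 1 to compound 2 (0.38 log units; beyond the scatter) is beyond the scatter. Both measured steps concern the same kind of change, trifluoromethyl in place of methyl on an aromatic carbon, once on the phenyl ring and once on the azole.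

Compound 4 `COc1cc2c(Oc3ccc(NC(=O)c4nnn(-c5ccccc5C(F)(F)F)c4C)cc3F)ccnc2cc1OCCCN1CCN(C)CC1` is not yet measured. It differs from compound 2 only at the chain amine: 4-methylpiperazin-1-yl in place of pyrrolidin-1-yl on a saturated chain carbon, three bonds along the chain from an oxygen on an aromatic ring. For the measured compounds named here, neither of the measured steps touches this part of the molecule, so none of them bears directly on the change; the data hold no precedent for an amine swap on the propoxy chain. With nothing to point in either direction, the expectation is a step of a 1.1-fold higher number from compound 2 to compound 4 (0.03 log units; within the scatter) that stays within the scatter of this assay. Compound 4 is therefore estimated at 170 nM in this assay, with a range from 70 nM to 450 nM.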

Compound 4, half-maximal inhibitory concentration: 200 nM
Estimate against measurement, compound 4: 1.2-fold (0.07 log units) below; the range from low to high includes it.
By their numbers in this assay, from the lowest: compounds 2, 3, 4 and 1 (each within the scatter of the next, the first and the last beyond it).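

In this assay the amine at the end of the propoxy chain gives its first reading in the series, and a 1.3-fold higher number from compound 2 to compound 4 (0.10 log units; within the scatter) shows that 4-methylpiperazin-1-yl and pyrrolidin-1-yl cannot be told apart on this background. The earlier steps shown here covered only trifluoromethyl in place of methyl, so this pair adds that a six-membered non-aromatic ring with 2 hetero atoms can take the place of a five-membered one with 1 hetero atom, on a saturated chain carbon, without a difference that can be read in this read-out. This holds for one pair only, and no measurement at hand speaks to why the two amines read alike.

Still open, as far as these compounds go, is whether a morpholine, a dimethylamino group or a carboxylic acid at the end of the chain, or a longer butyl chain in place of the propyl chain, would also stay level with compound 2 in this assay or would separate from it. Also open, from the compounds shown here alone, is whether the same amine swap reads alike when carried out on compound 1 or compound 3, which differ from compound 2 in the methyl and trifluoromethyl groups.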